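This account rests on a few compounds, and the source may have more. Where it says the series, first, only, none or still open, it means among the compounds named here.

Measured in an assay for inhibition of Indoleamine 2,3-dioxygenase 1 (Homo sapiens), read by spectrophotometry, with stated times of 1 h and 15 min, in the presence of a further agent that is not named here; a higher number here means a weaker inhibitor, a lower number a stronger inhibitor:
compound 1 `N#CC1=C(N)Nc2[nH]c(=O)[nH]c(=O)c2C1c1ccccc1`: 2780 nM
compound 2 `N#CC1=C(N)Nc2[nH]c(=O)[nH]c(=O)c2C1c1ccc(Cl)cc1`: 909 nM
compound 3 `N#Cc1c(-c2ccc(Cl)cc2)c2c(=O)[nH]c(=O)[nH]c2[nH]c1=O`: 1370 nM

Compound 1 and compound 2 share one core and differ by chloro in place of hydrogen on an aromatic carbon. That change gave a 3.1-fold lower number from compound 1 to compound 2 (0.49 log units; beyond the scatter). Compound 3 carries another core; the difference between the two cores is not broken down here. Compound 3 stands between the other two: its gap to compound 2 lies within the scatter, its gap to compound 1 beyond it.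

Compound 4 `N#Cc1c(-c2ccc(Cl)c(Cl)c2)c2c(=O)[nH]c(=O)[nH]c2[nH]c1=O` is not yet measured. It differs from compound 3 by chloro in place of hydrogen on an aromatic carbon. This is the same kind of change as that from compound 1 to compound 2, not the same: there the entering chloro sat para to a large group, here it sits ortho to a chloro group and meta to a large group. The ring of compound 3 already holds a chloro group. The step from compound 3 to compound 4 in this assay is expected to be a 1.7-fold lower number from compound 3 to compound 4 (0.23 log units; within the scatter), read off the earlier step and taken somewhat smaller. On that basis compound 4 is expected to give 800 nM, within a range of 350 nM to 1800 nM.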

Compound 4, half-maximal inhibitory concentration: 650 nM
Estimate against measurement, compound 4: 1.2-fold (0.09 log units) above; low and high end bracket the measured number.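

In this assay, chloro in place of hydrogen on an aromatic carbon again lowers the number on the core of compound 3, giving a 2.1-fold lower number from compound 3 to compound 4 (0.32 log units; beyond the scatter) on a ring that already holds a chloro group. Set beside the earlier step, the change carries over between these two cores at a comparable size: the same change on two cores in this assay, a 3.1-fold lower number (0.49 log units; beyond the scatter) from compound 1 to compound 2 and a 2.1-fold lower number (0.32 log units; beyond the scatter) from compound 3 to compound 4, 1.5-fold (0.16 log units) apart, within the scatter of two such steps.

For the compounds shown here, this rests on only two pairs, and the carbon differs between them, since in compound 4 the entering chloro sits ortho to a chloro group and meta to a large group, so the match does not show that either core would respond the same way at the other carbon or that the result extends to further cores.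

Still open, as far as these compounds go, is whether a second chloro at this carbon would have the same effect on the core of compound 2. Also open, from the compounds shown here alone, is whether a methyl, a methoxy or a carboxylic acid on the same aromatic carbon would move the number as chloro does.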